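The source may hold more compounds than are shown below. What is called first, only, known or untested is meant among the compounds shown, and "the series" means these compounds.

Compound 1, `O=C(N/N=C/c1ccccc1)c1cccnc1Nc1cccc(C(F)(F)F)c1`, gives 31% in a functional assay on the whole organism (strain Wistar) for inhibition, with Rattus norvegicus as the target, read by paw edema, with a stated time of 4 h, at a dose of 10 mg/kg by the intraperitoneal route; on this read-out higher numbers stand for more inhibition at the one dose given (going by the name of the read-out) and lower numbers for less inhibition. Compound 2, `O=C(N/N=C/c1ccc(O)c(O)c1)c1cccnc1Nc1cccc(C(F)(F)F)c1`, gives 21.1% in this assay. Compound 3, `COc1cccc(/C=N/NC(=O)c2cccnc2Nc2cccc(C(F)(F)F)c2)c1`, gives 14.9% in this assay.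

Compound 3 holds the lowest of the three numbers: its gap to compound 2 is within the scatter, while a number 16.1 percentage points lower from compound 1 to compound 3 (beyond the scatter) lies beyond it. Compound 4, `CN(C)c1ccc(/C=N/NC(=O)c2cccnc2Nc2cccc(C(F)(F)F)c2)cc1`, differs from compound 3 in one place: 4-(dimethylamino)phenyl in place of 3-methoxyphenyl on a carbon with a double bond to nitrogen. The steps that exchange groups on this carbon are a number 9.9 percentage points lower from compound 1 to compound 2 (within the scatter) and a number 6.2 percentage points lower from compound 2 to compound 3 (within the scatter), both within the scatter; only a number 16.1 percentage points lower from compound 1 to compound 3 (beyond the scatter) was beyond it. A step within the scatter in this assay is therefore expected for compound 4, with no clear direction. Compound 4 is estimated at 21% (range 8% to 36%), an expected step of a number 6.1 percentage points higher from compound 3 to compound 4 (within the scatter).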

Compound 4, a percentage reported as inhibition, in the whole organism at one dose (the size of the read-out at that dose, not a potency): 28.2%
Compound 4: middle estimate off by 7.2 percentage points, on the low side; the range from low to high includes it.
By their numbers in this assay, from the lowest: compounds 3, 2, 4 and 1 (each within the scatter of the next, the first and the last beyond it).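

In this assay, a group on the phenyl at this place does not by itself mean a low number: dimethylamino in place of hydrogen gives a number 2.8 percentage points lower from compound 1 to compound 4 (within the scatter), unlike methoxy in compound 3. The exchange of 3-methoxyphenyl for 4-(dimethylamino)phenyl gives a number 13.3 percentage points higher from compound 3 to compound 4 (beyond the scatter), whereas the exchange of 3,4-dihydroxyphenyl for 4-(dimethylamino)phenyl gives a number 7.1 percentage points higher from compound 2 to compound 4 (within the scatter). No measurement available here explains these steps.

Going by these compounds, whether the step follows the group or its place on the phenyl stays open, as the 3-methoxyphenyl and 4-(dimethylamino)phenyl names carry different numbers. On these data alone, how a primary amine or a carboxylic acid on the phenyl would read also stays open.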